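The source may report more compounds than this note shows. Statements on the series, on what has been measured and on what is new or still open speak of the compounds shown alone.

Two compounds have values in a functional assay on QG-56 cells (Homo sapiens) for antiproliferative activity (a lower number here means a stronger inhibitor, a higher number a weaker inhibitor), so far
- Compound 1 `COc1ccc(-c2cc([N+](=O)[O-])cc3cc(C(O)(c4ccc(C#N)cc4)c4cncn4C)oc23)cc1` gives 36 nM
- Compound 2 `Cn1cncc1C(O)(c1ccc(C#N)cc1)c1cc2cc([N+](=O)[O-])cc(-c3cccc(C#N)c3)c2o1` gives 22.9 nM

Compound 2 stands level with compound 1, since their two numbers lie within the usual scatter of each other and neither can be called the better inhibitor. Compound 3 `Cc1cccc(-c2cc([N+](=O)[O-])cc3cc(C(O)(c4ccc(C#N)cc4)c4cncn4C)oc23)c1` has not yet been measured. Its difference from compound 2 is methyl in place of cyano on an aromatic carbon and it amounts to methyl in place of cyano on an aromatic carbon, meta to a large group. Cut one bond further out, this reads 3-cyanophenyl to 3-methylphenyl.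

Among the compounds with values here, only one measured step bears on this change. It is a 1.6-fold lower number from compound 1 to compound 2 (0.20 log units; within the scatter) and it also exchanges the substituted phenyl group, yet it stays within the scatter. Within the data shown here, no measured compound carries the 3-methylphenyl group, so this single step offers only indirect guidance. No shift beyond the scatter is therefore expected in this assay, and the direction cannot be told with any confidence. The expected change is a 1.3-fold higher number from compound 2 to compound 3 (0.12 log units; within the scatter) and it remains within the scatter. Compound 3 is estimated at 30 nM with an expected range from 12 nM to 75 nM in this measurement.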

Compound 3, half-maximal inhibitory concentration: 23.2 nM
For compound 3 the middle estimate is 1.3-fold (0.11 log units) above the measured one, within the range that was stated.
By their numbers in this assay, from the lowest: compounds 2, 3 and 1 (each within the scatter of the next).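

In this assay, within the data shown here, replacing the nitrile with a methyl on the aromatic carbon, meta to a large group, gives a 1.0-fold higher number from compound 2 to compound 3 (0.01 log units; within the scatter) and is the first direct test of this single position: the cyano group brings a triple bond and a hydrogen-bond acceptor, the methyl neither, and in this pair that loss leaves the number within the scatter. The step of a 1.6-fold lower number from compound 1 to compound 3 (0.19 log units; within the scatter) adds a second exchange of the whole substituted phenyl group, 3-methylphenyl for 4-methoxyphenyl, so three different aryl groups on this shared core now give values that cannot be told apart in this assay. No supporting measurement is available to explain this tolerance of the change.

These three compounds span only a narrow choice of small substituents on that phenyl ring, so they cannot show whether the same holds for an amine, a carboxylic acid or a longer chain such as butyl at this carbon. They also leave open what a plain phenyl ring, with hydrogen in that place, would give.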